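The compounds below may be only part of what the source reports. "The series", "measured", "known", "first", "only" and "open" are said of these compounds alone.

Measured compounds and their values in a functional assay on MGC-803 cells (Homo sapiens) for antiproliferative activity, read by CCK-8 assay, with a stated time of 72 h, tested at 2 uM; a lower number here means a weaker effect, a higher number a stronger effect of the compound at the concentration tested:
- compound 1, `CC1CCCCN1C(=S)SCc1ccc(C(=O)Nc2ccccc2N)cc1`, gives 64.4%
- compound 2, `Nc1ccccc1NC(=O)c1ccc(CSC(=S)N2CCCc3ccccc32)cc1`, gives 38.5%
- compound 3, `Nc1ccccc1NC(=O)c1ccc(CSC(=S)N2CCN(C(c3ccccc3)c3ccccc3)CC2)cc1`, gives 9.8%

Compound 3 stands lowest of the three; compound 2 is nearest, and compound 1 is furthest above it. For the measured compounds named here, the only step between two measured compounds that differ in one place is a number 25.9 percentage points lower from compound 1 to compound 2 (beyond the scatter), and it concerns the ring on the thiocarbonyl carbon, not the group on the saturated chain carbon of the piperazine.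

Compound 4, `Nc1ccccc1NC(=O)c1ccc(CSC(=S)N2CCN(Cc3ccccc3)CC2)cc1`, differs from compound 3 in one place: hydrogen in place of phenyl on a saturated chain carbon bound to an amine nitrogen in a ring and an aromatic carbon. Going by the values given here, no measured step bears directly on this change, so there is no sound basis for expecting a move beyond the scatter in this assay, in either direction. The expected step is therefore small: a number 7.2 percentage points higher from compound 3 to compound 4 (within the scatter). For compound 4 the estimated value in this assay is 17%, with a range from 2% to 40%.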

Compound 4, a percentage reported as inhibition, at one concentration (the size of the read-out at that concentration, not a potency): 18.1%
Compound 4: middle estimate off by 1.1 percentage points, on the low side, and the stated range covers the measured number.
By their numbers in this assay, from the lowest: compounds 3 and 4 (each within the scatter of the next); then compound 2; then compound 1.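

With hydrogen in place of phenyl on a saturated chain carbon bound to an amine nitrogen in a ring and an aromatic carbon, the result is a number 8.3 percentage points higher from compound 3 to compound 4 (within the scatter) in this assay at the single concentration tested. For the compounds shown here, this is the first measured change at this position, and it shows that the assay cannot separate one phenyl from two on this carbon, unlike the earlier step, which concerned the whole ring on the thiocarbonyl carbon. No supporting measurement is available to explain this result.

As far as these compounds go, whether a methyl group or a carboxylic acid on this carbon would move the number beyond the scatter remains open. So does the effect of an amine or a longer chain in place of the remaining phenyl.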